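A Third Aromatic Ester on the Shared Core

The compounds below may be only part of what the source reports. "The series", "measured", "known", "first", "only" and "open" are said of these compounds alone.

Compound 1 `C=C1C(=O)[C@@]23C(=O)OC[C@]4([C@@H](OC(C)=O)CCC(C)(C)[C@H]4C=O)[C@@H]2CC[C@H]1[C@H]3OC(=O)c1ccc([N+](=O)[O-])cc1` and compound 2 `C=C1C(=O)[C@@]23C(=O)OC[C@]4([C@@H](OC(C)=O)CCC(C)(C)[C@H]4C=O)[C@@H]2CC[C@H]1[C@H]3OC(=O)c1ccc(C)cc1` share one core and differ only in the aromatic ester. In a functional assay on CaEs17 cells (Homo sapiens) for inhibition, read by MTT assay (on this read-out higher numbers stand for weaker inhibition and lower numbers for stronger inhibition), compound 1 gives 1600 nM, while compound 2 gives 1830 nM. Among the compounds with values here, the single measured step, a 1.1-fold higher number from compound 1 to compound 2 (0.06 log units; within the scatter), shows that exchanging these two groups barely moves the read-out. Among the two values, compound 2 sits within the scatter of compound 1, so the two cannot be told apart as inhibitors. Compound 3 `C=C1C(=O)[C@@]23C(=O)OC[C@]4([C@@H](OC(C)=O)CCC(C)(C)[C@H]4C=O)[C@@H]2CC[C@H]1[C@H]3OC(=O)c1ccccc1Cl` is the next variation: 2-chlorophenyl in place of 4-methylphenyl on a carbonyl carbon. Within the data shown here, only that one step bears on this change, and it lay within the scatter, so a step of similarly negligible size is expected, namely a 1.0-fold lower number from compound 2 to compound 3 (0.01 log units; within the scatter). For compound 3 the estimated value in this assay is 1800 nM, with a range from 900 nM to 3600 nM.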

Compound 3, half-maximal inhibitory concentration: 600 nM
Compound 3: the middle estimate sits 3.0-fold (0.48 log units) above what was measured; the whole stated range lies above it.
By their numbers in this assay, from the lowest: compound 3; then compounds 1 and 2 (each within the scatter of the next).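

The aromatic group on this carbonyl carbon is not as indifferent as compound 1 and compound 2 suggested, since in this assay the change to 2-chlorophenyl gives a 3.1-fold lower number from compound 2 to compound 3 (0.48 log units; beyond the scatter) and, set against the 4-nitrophenyl ester, a 2.7-fold lower number from compound 1 to compound 3 (0.43 log units; beyond the scatter). Both steps are modest but beyond the scatter, so this position can move the read-out even though exchanging 4-nitrophenyl for 4-methylphenyl did not. Nothing available explains why this group gives the lower number.

Compound 3 differs from compound 1 and compound 2 both in the group it carries and in where that group sits on the ring, so the chlorine and its placement cannot be separated. A 4-chlorophenyl or 2-methylphenyl ester would pull the two apart, and a 2-aminophenyl ester would show how far other groups at that place carry the change.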